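Methyl on the Amine Nitrogen, Tested Across Two Cores

The compounds below may be only part of what the source reports. "The series", "measured", "known", "first", "only" and "open" are said of these compounds alone.

Compound 1 `C=C(c1ccc(OC)cc1NC(=O)CN)c1ccc(OC)c2c1OC(C)(C)C=C2` and compound 2 `C=C(c1cc(OC)c(OC)c(OC)c1)c1ccc(OC)cc1NC(=O)CN` carry the same amide side chain on different cores; the difference between the two cores is not broken down here. In a functional assay on HeLa cells (Homo sapiens) for antiproliferative activity, read by MTT assay, with a stated time of 48 h (on this read-out lower numbers stand for stronger inhibition and higher numbers for weaker inhibition), compound 1 gives 120 nM, and compound 2 gives 70 nM, a gap within the usual scatter. Compound 3 `C=C(c1ccc(OC)cc1NC(=O)CNC)c1ccc(OC)c2c1OC(C)(C)C=C2` differs from compound 1 by methyl in place of hydrogen on an amine nitrogen. In this assay compound 3 gives 310 nM, so that a 2.6-fold higher number from compound 1 to compound 3 (0.41 log units; beyond the scatter). Compound 4 `C=C(c1cc(OC)c(OC)c(OC)c1)c1ccc(OC)cc1NC(=O)CNC` makes the same change on the core of compound 2, namely (methyl in place of hydrogen on an amine nitrogen). Among the compounds with values here, for compound 4 a step of like size is expected, a 2.6-fold higher number from compound 2 to compound 4 (0.41 log units; beyond the scatter), because the one earlier instance of this change gave a 2.6-fold higher number from compound 1 to compound 3 (0.41 log units; beyond the scatter). Compound 4 is therefore estimated at 180 nM, expected to lie between 90 nM and 400 nM, on the strength of a single precedent.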

Compound 4, half-maximal inhibitory concentration: 140 nM
Compound 4: the middle estimate sits 1.3-fold (0.11 log units) above what was measured; the measured number falls inside the stated range.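

Putting methyl in place of hydrogen on the amine nitrogen of the second core gives a 2.0-fold higher number from compound 2 to compound 4 (0.30 log units; within the scatter) in this assay. Set beside the earlier step, this one cannot be told apart from it: the same change on two cores in this assay, a 2.6-fold higher number (0.41 log units; beyond the scatter) from compound 1 to compound 3 and a 2.0-fold higher number (0.30 log units; within the scatter) from compound 2 to compound 4, 1.3-fold (0.11 log units) apart, within the scatter of two such steps

So, as far as these two pairs can show, the change carries from one core to the other with a similar size, but two pairs make no rule, and the second step alone cannot be separated from ordinary assay scatter.

Still open, from the compounds shown here alone, is how ethyl in place of methyl on that nitrogen, or a dimethylamino group in place of the methylamino group, would behave. Also open, going by these compounds, is whether the same step holds on any further core.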